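Tetrazole substituent series: from aryl to benzyl

This account rests on a few compounds, and the source may have more. Where it says the series, first, only, none or still open, it means among the compounds named here.

Measured compounds:
compound 1 `CCCCCCCCc1ccc(OCC(=O)Cn2nnnc2SC)cc1` 22 nM
compound 2 `CCCCCCCCc1ccc(OCC(=O)Cn2nnnc2-c2ccccc2Cl)cc1` 4600 nM
compound 3 `CCCCCCCCc1ccc(OCC(=O)Cn2nnnc2-c2cccc(S(=O)(=O)N(C)C)c2)cc1` 1900 nM

In an assay on microsomes from brain for inhibition of Fatty-acid amide hydrolase 1 (Rattus norvegicus), read by fluorescence and HPLC, with a stated time of 60 min (a lower number here means a stronger inhibitor, a higher number a weaker inhibitor), compound 3 stands second highest of the three numbers, nearest compound 2 and farthest from compound 1. Compound 4 `CCCCCCCCc1ccc(OCC(=O)Cn2nnnc2Cc2ccccc2)cc1` differs from compound 3 by benzyl in place of 3-(dimethylsulfamoyl)phenyl on an aromatic carbon. Within the data shown here, no measured step swaps an aryl group for a benzyl group on the shared core. The steps that touch this position are an 86-fold higher number from compound 1 to compound 3 (1.94 log units; beyond the scatter), a 210-fold higher number from compound 1 to compound 2 (2.32 log units; beyond the scatter) and a 2.4-fold lower number from compound 2 to compound 3 (0.38 log units; beyond the scatter): both aromatic groups give much higher numbers than methylsulfanyl, while the two aromatic groups differ only modestly from each other. A modest step to a lower number, a 2.4-fold lower number from compound 3 to compound 4 (0.38 log units; beyond the scatter), is therefore expected, with wide uncertainty. For compound 4 the estimate in this assay is 800 nM, range 120 nM to 5000 nM.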

Compound 4, half-maximal inhibitory concentration: 320 nM
Beside the measured number, compound 4's estimate is 2.5-fold (0.40 log units) above it; low and high end bracket the measured number.
By their numbers in this assay, from the lowest: compound 1; then compound 4; then compound 3; then compound 2.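

In this assay, benzyl gives a clearly lower number than either aryl group, with a 5.9-fold lower number from compound 3 to compound 4 (0.77 log units; beyond the scatter) and a 14-fold lower number from compound 2 to compound 4 (1.16 log units; beyond the scatter) as the two steps. It still falls short of methylsulfanyl, with a 15-fold higher number from compound 1 to compound 4 (1.16 log units; beyond the scatter), so the substituent on this aromatic carbon can recover part of the aryl loss but, among these four compounds, not all of it. Nothing measured here accounts for this order.

Open, on these data alone, is whether phenethyl, or a benzyl bearing chlorine or dimethylsulfamoyl, would move the number further. A plain phenyl on the shared core would show how much of the gain belongs to the methylene link itself.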